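The source may hold more compounds than are shown below. What is called first, only, known or untested is meant among the compounds shown, and "the series" means these compounds.

Working notes on the series

Going by the values given here, compound 1 `COc1cc(/C=C2\CN(C)C/C(=C\c3ccc(Cl)cc3Cl)C2=O)cc(OC)c1` is the first of three measured entries. In a functional assay on K562 cells (Homo sapiens) for cytotoxicity, read by MTT assay, with a stated time of 24 h (on this read-out higher numbers stand for weaker inhibition and lower numbers for stronger inhibition), compound 1 gives 11900 nM. Compound 2 `COc1cc(/C=C2\CN(C)C/C(=C\c3ccc(Cl)c(Cl)c3)C2=O)cc(OC)c1` carries the change 3,4-dichlorophenyl in place of 2,4-dichlorophenyl on a double-bonded chain carbon bound to a double-bonded ring carbon relative to compound 1, and in this assay compound 2 gives 9490 nM. The step is a 1.3-fold lower number from compound 1 to compound 2 (0.10 log units; within the scatter). Compound 3 `CN1C/C(=C\c2cccc([N+](=O)[O-])c2)C(=O)/C(=C/c2ccc(Cl)cc2Cl)C1` has a different core; the difference between the two cores is not broken down here. In this assay compound 3 gives 12400 nM, and the three measured values all lie within the scatter of one another, so no order among them is read.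

Compound 4 `CN1C/C(=C\c2cccc([N+](=O)[O-])c2)C(=O)/C(=C/c2ccc(Cl)c(Cl)c2)C1` has not yet been measured in this assay. It stands to compound 3 as compound 2 stands to compound 1: the change is 3,4-dichlorophenyl in place of 2,4-dichlorophenyl on a double-bonded chain carbon bound to a double-bonded ring carbon, the same change, at the same place. Among the compounds with values here, the expected step is a 1.3-fold lower number from compound 3 to compound 4 (0.10 log units; within the scatter), resting on the single precedent a 1.3-fold lower number from compound 1 to compound 2 (0.10 log units; within the scatter) between compound 1 and compound 2, which is itself within the scatter. For compound 4 the estimate in this assay is 9900 nM, expected to fall between 5000 nM and 20000 nM.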

Compound 4, half-maximal inhibitory concentration: 15500 nM
Beside the measured number, compound 4's estimate is 1.6-fold (0.19 log units) below it; measured number inside the range.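

In this assay, 3,4-dichlorophenyl in place of 2,4-dichlorophenyl on a double-bonded chain carbon bound to a double-bonded ring carbon gives a 1.3-fold higher number from compound 3 to compound 4 (0.10 log units; within the scatter), so on this core too the change stays within the scatter. Set beside the earlier step, the change shows no difference between the two cores: the same change on two cores in this assay, a 1.3-fold lower number (0.10 log units; within the scatter) from compound 1 to compound 2 and a 1.3-fold higher number (0.10 log units; within the scatter) from compound 3 to compound 4, 1.6-fold (0.20 log units) apart, within the scatter of two such steps. This supports only a modest reading, that the change is small on both cores in this assay; the opposite directions of the two steps mark no reversal, and two pairs within the scatter establish no direction that could be carried to a further core.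

The compounds shown vary the aromatic groups only among dichlorophenyl and the groups of the two cores, so it remains open whether an amine or a carboxylic acid on the aromatic ring would give a step beyond the scatter. Also open, from the compounds shown here alone, is whether a longer chain in place of the methyl on the ring nitrogen would change the number.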